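Swapping a Phenol Ring for a Fluorophenyl Ring

The source may hold more compounds than are shown below. What is called first, only, known or untested is meant among the compounds shown, and "the series" means these compounds.

Two compounds share one core and differ only in the ring attached to a nitrogen on an aromatic ring. Compound 1 `Cc1ccc(S(=O)(=O)c2nc3ccccc3nc2Nc2ccc(N)cc2)cc1` carries a 4-aminophenyl group, and in a functional assay on PC-3 cells (Homo sapiens) for cytotoxicity, read by MTT assay, with a stated time of 72 h (a higher number here means a weaker inhibitor, a lower number a stronger inhibitor), compound 1 gives 5000 nM. Within the data shown here, compound 2 `Cc1ccc(S(=O)(=O)c2nc3ccccc3nc2Nc2cccc(O)c2)cc1` carries a 3-hydroxyphenyl group, and in this assay compound 2 gives 1690 nM, the lowest of the two numbers measured so far. Among the measured compounds shown here, the single known step, a 3.0-fold lower number from compound 1 to compound 2 (0.47 log units; beyond the scatter), shows that exchanging this ring moved the result by a modest amount. Compound 3 `Cc1ccc(S(=O)(=O)c2nc3ccccc3nc2Nc2ccc(F)cc2)cc1` is the next analogue: 4-fluorophenyl in place of 3-hydroxyphenyl on a nitrogen on an aromatic ring. For the measured compounds named here, no measured step covers this exact exchange; the one known step altered a different pair of groups, so it gives only a loose sense of scale. The expected step is a 1.8-fold higher number from compound 2 to compound 3 (0.25 log units; within the scatter). Compound 3 is estimated at 3000 nM, with a range from 1000 nM to 9000 nM.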

Compound 3, half-maximal inhibitory concentration: 13100 nM
Compound 3: the middle estimate sits 4.4-fold (0.64 log units) below what was measured; measured number outside the range, above it.
By their numbers in this assay, from the lowest: compound 2; then compound 1; then compound 3.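

Exchanging 3-hydroxyphenyl for 4-fluorophenyl gives a 7.8-fold higher number from compound 2 to compound 3 (0.89 log units; beyond the scatter) in this assay and so shows that the ring on this nitrogen can move the result further than the earlier step did. Fluoro in place of amino on an aromatic carbon gives a 2.6-fold higher number from compound 1 to compound 3 (0.42 log units; beyond the scatter) as well, which leaves compound 3 with the highest number of the three and makes it the weakest inhibitor here. Nothing available explains this order.

From compound 2 to compound 3, both the group and its printed ring number change, and these two changes cannot be separated with the compounds shown. As far as these compounds go, it remains open how a plain phenyl ring, or a chloro or methoxy group on this ring, would compare with these three.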